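Swapping the Aryl Group on an Amide Nitrogen

The source may report more compounds than this note shows. Statements on the series, on what has been measured and on what is new or still open speak of the compounds shown alone.

In a functional assay on HEK293 cells for agonist activity at D(4) dopamine receptor (Homo sapiens), read by FLIPR (a lower number here means that less compound is needed, a higher number that more compound is needed for the effect), compound 1 `O=C(CN1CCC(c2cccc[n+]2[O-])CC1)Nc1ccc(F)cc1F` gives 103 nM, the lowest number among the three compounds measured. Compound 2 `Cc1ccc(Cl)c(NC(=O)CN2CCC(c3cccc[n+]3[O-])CC2)c1Cl` gives 346 nM and compound 3 `N#Cc1cccc(C(=O)NCN2CCC(c3cccc[n+]3[O-])CC2)c1` gives 840 nM; both lie beyond the usual scatter from compound 1. Compound 4 `Cc1cccc(C)c1NC(=O)CN1CCC(c2cccc[n+]2[O-])CC1` has not yet been measured. It differs from compound 1 in one place: 2,6-dimethylphenyl in place of 2,4-difluorophenyl on an amide-type nitrogen. Within the data shown here, no pair of measured compounds shows this exact change, so its effect can only be estimated. The nearest comparison is compound 2, which carries a differently substituted aromatic ring on the same amide nitrogen and gives 346 nM, a higher number than compound 1. A modest rise in this assay is therefore expected, with the step of a 2.1-fold higher number from compound 1 to compound 4 (0.33 log units; beyond the scatter) pointing toward more compound being needed. Compound 4 is expected to give about 220 nM, within a range from 60 nM to 800 nM.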

Compound 4, half-maximal effective concentration: 346 nM
Beside the measured number, compound 4's estimate is 1.6-fold (0.20 log units) below it, within the range that was stated.
By their numbers in this assay, from the lowest: compound 1; then compounds 2 and 4 (each within the scatter of the next); then compound 3.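

In this assay, among these compounds, the swap to 2,6-dimethylphenyl from 2,4-difluorophenyl brings a 3.4-fold higher number from compound 1 to compound 4 (0.53 log units; beyond the scatter) and gives the first direct reading at this position. The two groups match in heavy-atom count and each has one carbon-only aromatic ring, yet the number still moves, so what this ring carries matters here. Nothing shown explains the rise.

On these data alone, whether the methyl groups or the loss of the fluorines drive it stays open. So does how a plain phenyl, or a ring bearing an amine or a carboxylic acid, would read here.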